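Urea series: cytotoxicity on cells, ethyl for trifluoromethoxy

A few compounds are considered here, and "the series" means these few. Any claim that something is new, unique, unknown or untested is made for them only; others in the source may bear on it.

Compound 1 `COc1ccc(NC(=O)Nc2cc(C)nc3ccccc23)cc1` gives in an ADME assay on HEK293 cells (Homo sapiens) for cytotoxicity, with a stated time of 72 h; on this read-out higher numbers stand for an effect only at larger amounts of compound and lower numbers for an effect already at smaller amounts > 25000 nM, a limit of the assay.
Compound 2 `Cc1cc(NC(=O)Nc2ccc(C(N)=O)cc2)c2ccccc2n1` gives in this assay > 25000 nM, also a limit.
Compound 3 `Cc1cc(NC(=O)Nc2ccc(OC(F)(F)F)cc2)c2ccccc2n1` gives in this assay 14000 nM.

Compound 3 thus holds the only number shown; the other two values are limits (the limit of > 25000 nM in this assay, at which 2 of the 3 values shown sit). Compound 4 `CCc1ccc(NC(=O)Nc2cc(C)nc3ccccc23)cc1` differs from compound 3 by ethyl in place of trifluoromethoxy on an aromatic carbon. The measured steps that touch compound 3 are an at least 1.7-fold lower number from compound 1 to compound 3 (0.25 log units; that floor lies within the scatter) and an at least 1.7-fold lower number from compound 2 to compound 3 (0.25 log units; that floor lies within the scatter); both are only floors that lie within the scatter. A further step, a step that the two limits leave unreadable from compound 1 to compound 2, is unreadable. So far no change on this ring has moved the read-out beyond the scatter, and for compound 4 no step beyond it is expected, the estimated step being a 1.4-fold higher number from compound 3 to compound 4 (0.15 log units; within the scatter). Compound 4 is expected at 20000 nM, between 8000 nM and 50000 nM, with a fair chance that only a limit is reported.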

Compound 4, half-maximal effective concentration: 16000 nM
The estimate for compound 4 lay 1.3-fold (0.10 log units) above the measured number; measured number inside the range.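

In this assay, for the compounds shown here, the first step between two actual numbers at this position is ethyl in place of trifluoromethoxy, a 1.1-fold higher number from compound 3 to compound 4 (0.06 log units; within the scatter), so losing the oxygen and all three fluorines leaves the read-out within the scatter. Against the other two compounds only floors can be read: an at least 1.5-fold lower number from compound 2 to compound 4 (0.19 log units; that floor lies within the scatter) and an at least 1.5-fold lower number from compound 1 to compound 4 (0.19 log units; that floor lies within the scatter). Part of the series still sits at a limit, not a number: the limit of > 25000 nM in this assay, at which 2 of the 4 values shown sit.

From the compounds shown here alone, whether an amine, a carboxylic acid or a longer chain at this position would move the read-out beyond the scatter stays open. Going by these compounds, the effect of any change to the shared core also stays open.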